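The source may hold more compounds than are shown below. What is called first, only, known or untested is meant among the compounds shown, and "the series" means these compounds.

Measured compounds:
- compound 1: `Cn1nnnc1SCC(=O)N/N=C/c1ccc(F)cc1`, an ADME assay on NIH3T3 cells (Mus musculus) for cytotoxicity, read by XTT assay, with a stated time of 24 h (a higher number here means a weaker inhibitor, a lower number a stronger inhibitor), 10000000 nM
- compound 2: `Cn1nnnc1SCC(=O)N/N=C/c1ccc(Br)cc1`, in this assay compound 2 gives 10000000 nM

Compound 2 stands level with compound 1 on the numbers shown; the step of no change at the digits printed from compound 1 to compound 2 (within the scatter) is the only measured step in the series, and it is flat.

Compound 3, `CN(C)c1ccc(/C=N/NC(=O)CSc2nnnn2C)cc1`, is not yet measured in this assay. Relative to compound 2 it carries the change (dimethylamino in place of bromo on an aromatic carbon). Among the compounds with values here, no measured step exchanges a halogen for a dimethylamino group, so the only step that bears on this change is the halogen swap from compound 1 to compound 2, which gave no change in this assay. Both measured compounds sit at the same value, and nothing in the series shows the shared core responding to a change at this aromatic carbon. The expectation is therefore no step beyond the scatter: the estimated step is no change at the digits printed from compound 2 to compound 3 (within the scatter).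

On that basis compound 3 is expected to give about 10000000 nM in this assay, with a range from 3000000 nM to 10000000 nM.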

Compound 3, half-maximal inhibitory concentration: 316000 nM
The estimate for compound 3 lay 32-fold (1.50 log units) above the measured number, and the stated range ends above it.
By their numbers in this assay, from the lowest: compound 3; then compounds 1 and 2 (each within the scatter of the next).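

In this assay this aromatic carbon, para to a large group, turns out to be able to move the read-out: dimethylamino in place of bromo gives a 32-fold lower number from compound 2 to compound 3 (1.50 log units; beyond the scatter) and dimethylamino in place of fluoro gives a 32-fold lower number from compound 1 to compound 3 (1.50 log units; beyond the scatter). The halogen swap alone gave no change at the digits printed from compound 1 to compound 2 (within the scatter), so the flat pair of compounds 1 and 2 did not mean that the series is insensitive at this position; it showed only that exchanging one of these halogens for the other leaves the number in place. No measurement at hand explains the drop in number seen with the dimethylamino group.

Going by these compounds, with a single non-halogen group at this carbon, it stays open whether the step belongs to dimethylamino specifically or would also appear with a primary amine, a diethylamino group or a methoxy group. On these data alone, whether a carboxylic acid or a nitrile at the same carbon would leave the number level with the halogens or lower it is equally open.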